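The source may report more compounds than this note shows. Statements on the series, on what has been measured and on what is new or still open speak of the compounds shown alone.

Of the compounds shown here, three built on one shared core have been tested in a functional assay on UACC-62 cells (Homo sapiens) for cytotoxicity, read by sulforhodamine B assay, with a stated time of 48 h, tested at 1 uM; a lower number here means a stronger effect, a higher number a weaker effect of the compound at the concentration tested. Compound 1 `COc1cc(-c2cc(/C=C/C(=O)c3ccc(N)cc3)[nH]n2)cc(OC)c1OC` gives 86% in this assay. Compound 2 `COc1ccc(C(=O)/C=C/c2cc(-c3cc(OC)c(OC)c(OC)c3)n[nH]2)cc1OC` gives 95%, and compound 3 `COc1ccc(C(=O)/C=C/c2cc(-c3cc(OC)c(OC)c(OC)c3)n[nH]2)cc1` gives 95%. Compound 3 therefore stands level with compound 2 at the digits reported, and the two of them sit together at the top of the three numbers, with compound 1 the furthest away, the step of a number 9 percentage points higher from compound 1 to compound 3 (within the scatter) lying within the scatter.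

The next compound, compound 4 `COc1cc(-c2cc(/C=C/C(=O)c3ccc(F)c(F)c3)[nH]n2)cc(OC)c1OC`, differs from compound 3 in one place: 3,4-difluorophenyl in place of 4-methoxyphenyl on a carbonyl carbon. For the measured compounds named here, the steps that bear on this change are the ones that alter the same aryl group on the carbonyl carbon. The step of a number 9 percentage points higher from compound 1 to compound 2 (within the scatter), the step of a number 9 percentage points higher from compound 1 to compound 3 (within the scatter) and the step of no change at the digits printed from compound 2 to compound 3 (within the scatter) all stayed within the scatter, so exchanging substituents on this aryl group has so far left the read-out essentially where it was. Compound 4 is therefore expected to show no step beyond the scatter, the expected step being a number 2 percentage points lower from compound 3 to compound 4 (within the scatter). The estimate for compound 4 is 93%, with a range from 80% to 102%.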

Compound 4, a percentage reported as activity, at one concentration (the size of the read-out at that concentration, not a potency): 88%
Compound 4: middle estimate off by 5 percentage points, on the high side; low and high end bracket the measured number.
By their numbers in this assay, from the lowest: compounds 1, 4, 2 and 3 (each within the scatter of the next).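

In this assay, for the compounds shown here, the carbonyl carbon now carries a fluorine-bearing aryl group for the first time, and this exchange gives a number 7 percentage points lower from compound 3 to compound 4 (within the scatter) and a number 7 percentage points lower from compound 2 to compound 4 (within the scatter) and also a number 2 percentage points higher from compound 1 to compound 4 (within the scatter). The earlier compounds shown here had only varied amino and methoxy substituents on this aryl group, whereas these steps show that 3,4-difluorophenyl also leaves all the compounds within the scatter of one another, even though the computed hydrogen-bond acceptor count of the group goes from 1 in 4-methoxyphenyl to 0 in 3,4-difluorophenyl. Nothing available explains these numbers or gives a measured property of the groups involved.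

Going by these compounds, it remains open whether a carboxylic acid or a trifluoromethyl group on this aryl ring, or a longer alkyl chain in place of the ring on the carbonyl carbon, would move the read-out beyond the scatter. Also open, on these data alone, is whether the four aryl groups would separate at a higher concentration, since the single concentration tested here gives the size of the read-out and not a potency.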